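This account rests on a few compounds, and the source may have more. Where it says the series, first, only, none or still open, it means among the compounds named here.

Measured compounds:
Compound 1 `Cc1ccccc1N(C)C(=O)c1ccc(-c2cccc(O)c2)o1` gives 150 nM in an assay on cytosol from placenta for inhibition of 17-beta-hydroxysteroid dehydrogenase type 1 (Homo sapiens), read by HPLC, with a stated time of 10 min, in the presence of a further agent that is not named here; a lower number here means a stronger inhibitor, a higher number a weaker inhibitor.
Compound 2 `Cc1ccc(F)cc1N(C)C(=O)c1ccc(-c2ccc(O)cc2)o1` gives 41 nM in this assay.
Compound 3 `Cc1cc(F)ccc1N(C)C(=O)c1ccc(-c2ccc(O)cc2)o1` gives 23 nM in this assay.

Among these three numbers compound 2 stands second highest. Its nearest neighbour is compound 3, and the gap a 1.8-fold lower number from compound 2 to compound 3 (0.25 log units; within the scatter) lies within the scatter. Compound 1 stands furthest from compound 2, beyond the scatter, but compound 1 also carries its hydroxyl on a different ring position, so that gap is not a single-place step.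

Compound 4 `Cc1ccncc1N(C)C(=O)c1ccc(-c2ccc(O)cc2)o1` differs from compound 2 by 4-methylpyridin-3-yl in place of 5-fluoro-2-methylphenyl on an amide-type nitrogen. Among the measured compounds shown here, no measured compound carries the 4-methylpyridin-3-yl group, and the one single-place step that is known, a 1.8-fold lower number from compound 2 to compound 3 (0.25 log units; within the scatter), only shifts the fluorine on the same carbon ring and stays within the scatter. For the measured compounds named here, there is thus no measured step that bears directly on the change, and nothing in the data points to a large move in either direction in this assay.

The account therefore expects compound 4 to give 60 nM, in a range from 20 nM to 200 nM. The step of a 1.5-fold higher number from compound 2 to compound 4 (0.17 log units; within the scatter) is estimated to stay within the scatter.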

Compound 4, half-maximal inhibitory concentration: 260 nM
For compound 4 the middle estimate is 4.3-fold (0.64 log units) below the measured one; measured number outside the range, above it.
By their numbers in this assay, from the lowest: compounds 3 and 2 (each within the scatter of the next); then compounds 1 and 4 (each within the scatter of the next).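

In this assay, among the compounds shown here, the group on the amide-type nitrogen turns out to matter far more than the earlier compounds suggested. Moving the fluorine on the carbon ring stayed within the scatter, whereas 4-methylpyridin-3-yl gives a 6.3-fold higher number from compound 2 to compound 4 (0.80 log units; beyond the scatter) and an 11-fold higher number from compound 3 to compound 4 (1.05 log units; beyond the scatter). In both pairs, the ring with one hetero atom and one hydrogen-bond acceptor, lacking fluorine, gives the weaker inhibitor, and nothing measured here accounts for this.

The change replaces the ring carbon with nitrogen and removes the fluorine at once, so the compounds shown cannot separate these two differences. As far as these compounds go, it also remains open how the 4-methylpyridin-3-yl group would fare with a fluorine, a chlorine or a methoxy group added to its ring.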